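Sulfur-linked side chains on the shared core: toward compound 4

The source may hold more compounds than are shown below. What is called first, only, known or untested is meant among the compounds shown, and "the series" means these compounds.

Measured so far:
compound 1 `CC(C)c1n[nH]c2c(NCc3ccc(-c4ccccn4)cc3)nc(SCCO)nc12` gives 48 nM
compound 2 `CC(C)c1n[nH]c2c(NCc3ccc(-c4ccccn4)cc3)nc(SCC3CNC(=O)O3)nc12` gives 80 nM
compound 3 `CC(C)c1n[nH]c2c(NCc3ccc(-c4ccccn4)cc3)nc(SC(C)C(C)O)nc12` gives 190 nM

All three numbers come from a functional assay on HT cells (Homo sapiens) for antiproliferative activity, read by fluorescence, with a stated time of 72 h; on this read-out higher numbers stand for weaker inhibition of growth and lower numbers for stronger inhibition of growth. Compound 2 stands second highest of the three in this assay: the step of a 1.7-fold higher number from compound 1 to compound 2 (0.22 log units; within the scatter) is its closest, and the step of a 2.4-fold higher number from compound 2 to compound 3 (0.38 log units; beyond the scatter) its widest.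

The next member is compound 4 `CC(C)c1n[nH]c2c(NCc3ccc(-c4ccccn4)cc3)nc(SCCCN)nc12`, not yet measured. Its change from compound 2 is 2-aminoethyl in place of 2-oxo-1,3-oxazolidin-5-yl on a saturated chain carbon bound to a sulfur, so the sulfur now carries a plain 3-aminopropyl chain instead of the ring-bearing (2-oxo-1,3-oxazolidin-5-yl)methyl.

Two kinds of step bear on this. The step of a 1.7-fold higher number from compound 1 to compound 2 (0.22 log units; within the scatter) shows that swapping a hydroxymethyl for the 2-oxo-1,3-oxazolidin-5-yl ring on this carbon moves the number only within the scatter. The steps of a 4.0-fold higher number from compound 1 to compound 3 (0.60 log units; beyond the scatter) and a 2.4-fold higher number from compound 2 to compound 3 (0.38 log units; beyond the scatter) show that the branched 2-hydroxy-1-methylpropyl chain costs a modest amount. Compound 4 is unbranched, like the 2-hydroxyethyl of compound 1, and its chain ends in one donor and one acceptor as counted above, so a step of modest size at most is expected, more likely toward a lower number, estimated as a 1.3-fold lower number from compound 2 to compound 4 (0.12 log units; within the scatter). Compound 4 is therefore expected to give 60 nM, with a range from 25 nM to 150 nM.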

Compound 4, concentration for 50% growth inhibition: 120 nM
Estimate against measurement, compound 4: 2.0-fold (0.30 log units) below; low and high end bracket the measured number.
By their numbers in this assay, from the lowest: compounds 1, 2, 4 and 3 (each within the scatter of the next, the first and the last beyond it).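

In this assay, the change of hydroxy to aminomethyl on a saturated chain carbon, two bonds along the chain from a sulfur, gives a 2.5-fold higher number from compound 1 to compound 4 (0.40 log units; beyond the scatter), so among the compounds shown, an unbranched chain on the sulfur does not by itself match compound 1, and this modest step joins the one to the branched chain of compound 3 as a change from compound 1 that lies beyond the scatter. The other two steps, a 1.5-fold higher number from compound 2 to compound 4 (0.18 log units; within the scatter) and a 1.6-fold lower number from compound 3 to compound 4 (0.20 log units; within the scatter), both lie within the scatter, so this assay does not separate compound 4 from either compound 2 or compound 3, even though the three chains differ in ring, branching and end group. No measurement is available that accounts for any of these steps.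

The step to compound 4 alters chain length and end group together, and a 3-hydroxypropyl or a 2-aminoethyl chain on the sulfur would be needed to tell those two changes apart. On these data alone, how a carboxylic acid or a dimethylamine at the end of the chain would read also remains open.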